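This account rests on a few compounds, and the source may have more. Where it says the series, first, only, none or still open, it means among the compounds named here.

Measured in a functional assay on RAW264.7 cells (Mus musculus) for inhibition, read by Griess assay, with stated times of 1 h and 24 h; a higher number here means a weaker inhibitor, a lower number a stronger inhibitor:
- compound 1 `CC(C)CCOc1ccccc1C1CC(=O)c2ccccc2O1`: 39200 nM
- compound 2 `CCCCOc1ccccc1C1CC(=O)c2ccccc2O1`: 48700 nM

Among the compounds with values here, compound 2 stands level with the only other measured compound. Compound 3 `O=C1CC(c2ccccc2OCc2cccc(F)c2)Oc2ccccc21` alters the chain of compound 2 (3-fluorophenyl in place of propyl on a saturated chain carbon bound to an oxygen on an aromatic ring): 3-fluorophenyl in place of propyl on a saturated chain carbon bound to an oxygen on an aromatic ring. Within the data shown here, the one measured step (a 1.2-fold higher number from compound 1 to compound 2 (0.09 log units; within the scatter)) stays within the scatter and brings in no ring, so it gives no direction for this change. In this assay the expected step is therefore none beyond the scatter (a 1.4-fold lower number from compound 2 to compound 3 (0.14 log units; within the scatter)). For compound 3 the estimated value is 35000 nM (range 12000 nM to 90000 nM).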

Compound 3, half-maximal inhibitory concentration: 15600 nM
Compound 3: middle estimate off by 2.2-fold (0.35 log units), on the high side; the measured number falls inside the stated range.
By their numbers in this assay, from the lowest: compound 3; then compounds 1 and 2 (each within the scatter of the next).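

In this assay, 3-fluorophenyl in place of propyl on a saturated chain carbon bound to an oxygen on an aromatic ring gives a 3.1-fold lower number from compound 2 to compound 3 (0.49 log units; beyond the scatter), and in place of isobutyl it gives a 2.5-fold lower number from compound 1 to compound 3 (0.40 log units; beyond the scatter). This position therefore responds beyond the scatter once an aromatic ring enters, which the step between the two saturated chains did not show. No evidence on hand accounts for the shift. The compounds shown leave open whether the ring alone carries this step or the fluorine also contributes, as a plain benzyl would show. On these data alone, how a chain ending in an amine would read at this position also remains open.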